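The compounds below may be only part of what the source reports. "The series", "measured", "known", "first", "only" and "open" are said of these compounds alone.

Measured compounds in a functional assay on MKN-74 cells (Homo sapiens) for antiproliferative activity, with a stated time of 24 h; a lower number here means a stronger inhibitor, a higher number a weaker inhibitor:
compound 1, `NC(=O)c1c(NC(=O)c2ccccc2C(F)(F)F)sc2c1CCN(C(=S)Nc1ccccc1Cl)C2`: 21900 nM
compound 3, `NC(=O)c1c(NC(=O)c2ccccc2C(F)(F)F)sc2c1CCN(C(=S)Nc1ccccc1Br)C2`: 23900 nM
compound 2, `Cc1ccccc1NC(=S)N1CCc2c(sc(NC(=O)c3ccccc3Br)c2C(N)=O)C1`: a limit of the assay, > 50000 nM

Compound 3 gives the higher of the two numbers shown; its nearest neighbour is compound 1 at 21900 nM, and the one measured step between them, a 1.1-fold higher number from compound 1 to compound 3 (0.04 log units; within the scatter), sits within the scatter. For compound 2 the assay reports only (the limit of > 50000 nM in this assay, at which 1 of the 3 values shown sits). Compound 4, `Cc1ccccc1NC(=S)N1CCc2c(sc(NC(=O)c3ccccc3C(F)(F)F)c2C(N)=O)C1`, is still to be measured; it differs from compound 3 by methyl in place of bromo on an aromatic carbon. Going by the values given here, no measured step covers methyl for bromo. Among the compounds with values here, the only pointer is that compound 2, which also carries the methyl, returned a limit, whereas chloro to bromo left the number essentially unchanged. A weakening step of a 1.5-fold higher number from compound 3 to compound 4 (0.17 log units; within the scatter) is therefore expected, with some chance of another limit. Compound 4 is estimated at 35000 nM, range 15000 nM to 90000 nM.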

Compound 4, half-maximal inhibitory concentration: 47400 nM
Estimate against measurement, compound 4: 1.4-fold (0.13 log units) below, within the range that was stated.
By their numbers in this assay, from the lowest: compounds 1, 3 and 4 (each within the scatter of the next, the first and the last beyond it). At a limit, above all of these: compound 2.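

With the trifluoromethyl group held constant, this assay shows a 2.2-fold higher number from compound 1 to compound 4 (0.34 log units; beyond the scatter), which separates methyl from chloro on this aromatic carbon, ortho to a large group, but only modestly, and a 2.0-fold higher number from compound 3 to compound 4 (0.30 log units; within the scatter), which does not separate methyl from bromo. Methyl in place of a halogen is therefore not a uniform step here, even though chloro and bromo lie within the scatter of each other.

As far as these compounds go, whether an amine or a methoxy group on this carbon would move the number further stays open. Going by these compounds alone, for trifluoromethyl in place of bromo there is only a floor (an at least 1.0-fold lower number from compound 2 to compound 4 (0.02 log units; that floor lies within the scatter)), which fixes no size for that step. Compound 2 stands at a limit: the limit of > 50000 nM in this assay, at which 1 of the 4 values shown sits.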